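A few compounds are considered here, and "the series" means these few. Any claim that something is new, unique, unknown or untested is made for them only; others in the source may bear on it.

Measured in an ADME assay on MT4 cells (Homo sapiens) for cytotoxicity, read by XTT assay, with a stated time of 5 days; a lower number here means that less compound is tolerated, a higher number that more compound is tolerated (both values are limits):
compound 1 `CNC(=O)[C@@H](NC(=O)[C@@](O)(CCCN(Cc1ccc(C#Cc2cccnc2)cc1)NC(=O)[C@@H](NC(=O)OC)C(C)(C)C)Cc1ccccc1)C(C)(C)C` gives > 50000 nM (a limit)
compound 2 `CNC(=O)[C@@H](NC(=O)[C@@](O)(CCCN(Cc1ccc(-c2ccccn2)cc1)NC(=O)[C@@H](NC(=O)OC)C(C)(C)C)Cc1ccccc1)C(C)(C)C` gives > 50000 nM (a limit)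

On these numbers, compound 2 stands at a limit and not at a measured number (> 50000 nM). Going by the values given here, the series so far offers only this (the limit of > 50000 nM in this assay, at which 2 of the 2 values shown sit), so no rank can be read from it. The change to compound 3 `CNC(=O)[C@@H](NC(=O)[C@@](O)(CCCN(Cc1ccc(-c2nccs2)cc1)NC(=O)[C@@H](NC(=O)OC)C(C)(C)C)Cc1ccccc1)C(C)(C)C` puts 1,3-thiazol-2-yl in place of pyridin-2-yl on an aromatic carbon, para to a large group (1,3-thiazol-2-yl in place of pyridin-2-yl on an aromatic carbon). Among the compounds with values here, the sole measured step at this place (a step that the two limits leave unreadable from compound 1 to compound 2) gives no size to carry over, so no step beyond the scatter is expected in this assay here. The expected step is therefore small (a number no higher from compound 2 to compound 3 (the limit leaves the size open)). Compound 3 is estimated at 50000 nM with an expected range from 25000 nM to 100000 nM (a report as a limit is also expected to be likely).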

Compound 3, half-maximal cytotoxic concentration: > 50000 nM
Compound 3: only a limit was reported; the forecaster's own chance of this, stated with the estimate: 80%; the middle value lies on the limit itself.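

In this assay compound 3 gives > 50000 nM as a limit. No new step can be read from compound 2 to compound 3 or from compound 1 to compound 3: the limit of > 50000 nM in this assay, at which 3 of the 3 values shown sit. The compounds shown leave open at what concentration any of compound 1, compound 2 and compound 3 becomes cytotoxic, and how far apart they lie.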